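This account rests on a few compounds, and the source may have more. Where it says the series, first, only, none or still open, it means among the compounds named here.

Compound 1, `Nc1ccc(-c2cc(=O)c3c(N)c(F)c(Br)c(F)c3o2)cc1F`, in a functional assay on HeLa cells (Homo sapiens) for cytotoxicity, read by neutral red uptake, with a stated time of 3 days (a lower number here means a stronger inhibitor, a higher number a weaker inhibitor), gives only a limit, > 100000 nM.
Compound 2, `CN(C)c1c(F)c(N)c2c(=O)cc(-c3ccc(N)c(F)c3)oc2c1F`, in this assay also gives only a limit, > 100000 nM.
Compound 3, `CCC(=O)OCc1c(F)c(N)c2c(=O)cc(-c3ccc(N)c(F)c3)oc2c1F`, in this assay gives 69000 nM.

Within the data shown here, compound 3 thus holds the only true number among the three, while the others sit at a limit (the limit of > 100000 nM in this assay, at which 2 of the 3 values shown sit). Compound 4, `CN(C)CCC(=O)OCc1c(F)c(N)c2c(=O)cc(-c3ccc(N)c(F)c3)oc2c1F`, differs from compound 3 by dimethylamino in place of hydrogen on a saturated chain carbon, two bonds along the chain from a carbonyl carbon. Among the measured compounds shown here, no measured step touches that chain. The steps ending at compound 3, an at least 1.4-fold lower number from compound 1 to compound 3 (0.16 log units; that floor lies within the scatter) and an at least 1.4-fold lower number from compound 2 to compound 3 (0.16 log units; that floor lies within the scatter), change an aromatic carbon instead and carry only a floor within scatter; the remaining step, a step that the two limits leave unreadable from compound 1 to compound 2, changes the same aromatic carbon. Compound 4 is therefore expected to show no step beyond the scatter, a 1.0-fold higher number from compound 3 to compound 4 (0.01 log units; within the scatter). The estimate for compound 4 is 70000 nM, between 30000 nM and 160000 nM.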

Compound 4, half-maximal inhibitory concentration: 11000 nM
Estimate against measurement, compound 4: 6.4-fold (0.80 log units) above, outside the stated range (below it).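

In this assay, among these compounds, dimethylamino on this saturated chain carbon gives a 6.3-fold lower number from compound 3 to compound 4 (0.80 log units; beyond the scatter), so this chain, which no earlier step touched, does affect the number. The change measured against the other two compounds also now reads beyond the scatter, with an at least 9.0-fold lower number from compound 2 to compound 4 (0.95 log units; beyond the scatter) and an at least 9.0-fold lower number from compound 1 to compound 4 (0.95 log units; beyond the scatter). Both of these are only floors, set by a limit: the limit of > 100000 nM in this assay, at which 2 of the 4 values shown sit.

The compounds shown leave open whether a pyrrolidine in place of dimethylamino, or a longer chain carrying it, would move the number further. They also leave open why this group lowers the number.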